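Adding a Second Chlorine Where Only Limits Are Known

A few compounds are considered here, and "the series" means these few. Any claim that something is new, unique, unknown or untested is made for them only; others in the source may bear on it.

Compound 2, `O=C(/C=C\c1ccccc1Cl)N1N=C(c2ccncc2)OC1c1c[nH]c2ccccc12`, was tested in an ADME assay on HeLa cells (Homo sapiens) for cytotoxicity, read by MTT assay, with a stated time of 72 h (a lower number here means a stronger inhibitor of growth, a higher number a weaker inhibitor of growth), where compound 2 gives > 30 ug/mL, a limit of the assay rather than a number. Compound 1, `O=C(/C=C\c1cccc(O)c1)N1N=C(c2ccncc2)OC1c1c[nH]c2ccccc12`, gives > 30 ug/mL in this assay, likewise a limit. The step that the two limits leave unreadable from compound 1 to compound 2 therefore cannot be read, since both values sit at the limit of > 30 ug/mL in this assay, at which 2 of the 2 values shown sit. Compound 3, `O=C(/C=C/c1c(Cl)cccc1Cl)N1N=C(c2ccncc2)OC1c1c[nH]c2ccccc12`, carries 2-(2,6-dichlorophenyl)ethenyl in place of 2-(2-chlorophenyl)ethenyl on a carbonyl carbon. No readable step bears on this change, so no direction beyond the scatter can be predicted. Compound 3 is expected at 40 ug/mL, within a range from 20 ug/mL to 100 ug/mL. The expected step that the limit leaves unreadable from compound 2 to compound 3 is thus essentially none.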

Compound 3, concentration for 50% growth inhibition: > 30 ug/mL
Compound 3: a limit, no number; the forecaster's own chance of this, stated with the estimate: 80%; the middle value does not contradict the limit.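

No new step can be read, since compound 1, compound 2 and compound 3 all give only a limit of the assay: the limit of > 30 ug/mL in this assay, at which 3 of the 3 values shown sit. The compounds shown leave open how strongly each inhibits growth in this assay, and whether changing the group on the carbonyl carbon alters that at all.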